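Quinazoline series: replacing the aryl amine substituent

The compounds below may be only part of what the source reports. "The series", "measured", "known", "first", "only" and "open" are said of these compounds alone.

Measured compounds in a functional assay on MGC-803 cells (Homo sapiens) for cytotoxicity, read by MTT assay, with a stated time of 72 h; on this read-out lower numbers stand for stronger inhibition and higher numbers for weaker inhibition:
- Compound 1, `CCCCCCCCNc1nc(SCc2ccc(C(F)(F)F)cc2)nc2ccccc12`, gives 12600 nM.
- Compound 3, `FC(F)(F)c1ccc(CSc2nc(Nc3cccc(Cl)c3)c3ccccc3n2)cc1`, gives 14600 nM.
- Compound 2, `FC(F)(F)c1ccc(CSc2nc(Nc3ccccc3C(F)(F)F)c3ccccc3n2)cc1`, gives only a limit of the assay, > 50000 nM.

Compound 2 therefore stands at the weak end of the three, as the only one reported as a limit (the limit of > 50000 nM in this assay, at which 1 of the 3 values shown sits). The step to compound 4, `CCOc1ccc(Nc2nc(SCc3ccc(C(F)(F)F)cc3)nc3ccccc23)cc1`, is 4-ethoxyphenyl in place of 2-(trifluoromethyl)phenyl on a nitrogen on an aromatic ring. Among the measured compounds shown here, the steps that bear on it are an at least 3.4-fold lower number from compound 2 to compound 3 (0.53 log units; beyond the scatter), which moved the compound back into the range of compound 1, and an at least 3.9-fold higher number from compound 1 to compound 2 (0.59 log units; beyond the scatter) together with a 1.2-fold higher number from compound 1 to compound 3 (0.06 log units; within the scatter), which together show that an aryl group other than 2-(trifluoromethyl)phenyl on that nitrogen gives a number close to compound 1. For compound 4 a step in the same direction as that to compound 3 is expected, an at least 3.3-fold lower number from compound 2 to compound 4 (0.52 log units; beyond the scatter), and compound 4 is estimated at 15000 nM, with a range of 5000 nM to 45000 nM in this assay.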

Compound 4, half-maximal inhibitory concentration: 37000 nM
Compound 4: middle estimate off by 2.5-fold (0.39 log units), on the low side; measured number inside the range.
By their numbers in this assay, from the lowest: compounds 1 and 3 (each within the scatter of the next); then compound 4. At a limit, above all of these: compound 2.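

In this assay, the aryl groups on this nitrogen do not all return to the level of compound 1: 3-chlorophenyl did, but 4-ethoxyphenyl gives a 2.9-fold higher number from compound 1 to compound 4 (0.47 log units; beyond the scatter) and a 2.5-fold higher number from compound 3 to compound 4 (0.40 log units; beyond the scatter). The step of an at least 1.3-fold lower number from compound 2 to compound 4 (0.13 log units; that floor lies within the scatter) offers only a floor within the scatter, so the replacement of 2-(trifluoromethyl)phenyl by 4-ethoxyphenyl cannot yet be counted as a clear gain. Compound 2 remains a limit of the assay rather than a number: the limit of > 50000 nM in this assay, at which 1 of the 4 values shown sits.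

The compounds shown leave open whether the rise with 4-ethoxyphenyl follows from the ethoxy group itself or from where it sits on the ring, which 4-chlorophenyl and 3-ethoxyphenyl would help separate. They also leave open how a shorter chain such as butyl on this nitrogen compares with octyl.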